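Removing the Amino Group from a Phenyl Nucleoside

This account rests on a few compounds, and the source may have more. Where it says the series, first, only, none or still open, it means among the compounds named here.

Compound 3 `COc1nc(N)nc2c1c(-c1ccccc1)cn2[C@@H]1O[C@H](CO)[C@@H](O)[C@H]1O` was tested in a functional assay on CEM-DNR-bulk cells (Homo sapiens), read by MTT assay, with a stated time of 72 h; on this read-out lower numbers stand for stronger inhibition and higher numbers for weaker inhibition. In this assay compound 3 reached only the limit of > 20000 nM, so no number is known for it; it stands at the limit of > 20000 nM in this assay, at which 2 of the 3 values shown sit. Compound 4 `COc1ncnc2c1c(-c1ccccc1)cn2[C@@H]1O[C@H](CO)[C@@H](O)[C@H]1O` differs from compound 3 in one place: hydrogen in place of amino on an aromatic carbon. For the measured compounds named here, no measured pair shows this same change. Going by the values given here, the one measured step, an at least 1.6-fold lower number from compound 1 to compound 2 (0.21 log units; that floor lies within the scatter), concerns another position. Compound 1 `COc1ncnc2c1c(I)cn2[C@@H]1O[C@H](CO)[C@@H](O)[C@H]1O` in this assay gives a limit of > 20000 nM. Compound 2 `COc1ncnc2c1c(-c1cccs1)cn2[C@@H]1O[C@H](CO)[C@@H](O)[C@H]1O` in this assay gives 12100 nM. With compound 2 as the only numbered point, compound 4 is expected to land near it, with a good chance of again reaching the limit. For compound 4 the estimated value is 15000 nM, between 5000 nM and 40000 nM. The expected step is an at least 1.3-fold lower number from compound 3 to compound 4 (0.12 log units; that floor lies within the scatter).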

Compound 4, half-maximal inhibitory concentration: > 20000 nM
Compound 4: no number, only a limit (the forecaster's own chance of this, stated with the estimate: 45%); at least 1.3-fold (0.12 log units) between middle value and limit.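

With hydrogen in place of amino, compound 4 gives > 20000 nM in this assay, which is again a limit and not a number. For the compounds shown here, the one readable step, with phenyl in place of thiophen-2-yl, is an at least 1.6-fold higher number from compound 2 to compound 4 (0.21 log units; that floor lies within the scatter). The steps from compound 3 and from compound 1 to compound 4 cannot be read, and limits now fill most of this short series: the limit of > 20000 nM in this assay, at which 3 of the 4 values shown sit.

On these data alone, whether the amino group matters at all therefore stays open. Also open, as far as these compounds go, is what a methyl group or a hydroxyl group would do on the aromatic carbon between two ring nitrogen atoms.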